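The compounds below may be only part of what the source reports. "The series", "measured", "known", "first", "only" and "open" are said of these compounds alone.

Two pairs of compounds are compared here. Compound 1 `COC(=O)[C@@]1(C)CCC=C2[C@@H]1CC[C@@H](C)[C@]2(C)Cc1c[nH]c2c(Br)cccc12` and compound 2 `COC(=O)[C@@]1(C)CCC=C2[C@@H]1CC[C@@H](C)[C@]2(C)Cc1c[nH]c2c(Cl)cccc12` share one core; compound 3 `COC(=O)[C@@]1(C)CC[C@@H]2C3=C1CC[C@@H](C)[C@]3(C)C[C@@H]1c3cc(Br)ccc3N[C@H]21` and compound 4 `COC(=O)[C@@]1(C)CC[C@@H]2C3=C1CC[C@@H](C)[C@]3(C)C[C@@H]1c3cc(Cl)ccc3N[C@H]21` share another, and the difference between the two cores is not broken down here.

In a functional assay on WiDr cells (Homo sapiens) for inhibition, read by sulforhodamine B assay, with a stated time of 48 h (on this read-out lower numbers stand for stronger inhibition of growth and higher numbers for weaker inhibition of growth), compound 1 gives 32000 nM and compound 2 gives 31000 nM. The change between them is chloro in place of bromo on an aromatic carbon, and it made a step of a 1.0-fold lower number from compound 1 to compound 2 (0.01 log units; within the scatter). Compound 3, tested in this assay, gives 55000 nM, a number that lies within the usual scatter of those for compound 1 and compound 2, so no order can be read among the three.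

Compound 4 is reached from compound 3 by chloro in place of bromo on an aromatic carbon. For the measured compounds named here, this is the same kind of change as the one from compound 1 to compound 2, though not the same: in compound 1 the place is part of a fused or bridged system of two rings, ortho to a fused ring and meta to a fused ring, while in compound 3 it is part of a fused or bridged system of five rings, meta to a fused ring and para to a fused ring.

Because the earlier step of a 1.0-fold lower number from compound 1 to compound 2 (0.01 log units; within the scatter) stayed within the scatter, a step of similar size, a 1.0-fold lower number from compound 3 to compound 4 (0.02 log units; within the scatter), is expected here. Compound 4 is therefore estimated to give about 53000 nM in this assay, most likely between 28000 nM and 100000 nM.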

Compound 4, concentration for 50% growth inhibition: 48000 nM
The estimate for compound 4 lay 1.1-fold (0.04 log units) above the measured number, within the range that was stated.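

In this assay, the exchange of bromo for chloro on the second core gives a 1.1-fold lower number from compound 3 to compound 4 (0.06 log units; within the scatter), so the number barely moves here, as it barely moved on the first core. Set side by side, the two steps agree: the same change on two cores in this assay, a 1.0-fold lower number (0.01 log units; within the scatter) from compound 1 to compound 2 and a 1.1-fold lower number (0.06 log units; within the scatter) from compound 3 to compound 4, 1.1-fold (0.05 log units) apart, within the scatter of two such steps

This shows that, for these two pairs, what was seen on one core held on the other, even though the aromatic carbon carrying the halogen sits in a different setting in each: on the second core it is meta to a fused ring and para to a fused ring. For the compounds shown here, it does not show that bromo and chloro are interchangeable across the series, since the evidence is only two pairs, and two steps that both stay within the scatter say little about how a change with a clear effect would carry over from one core to another.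

The compounds shown leave open whether a different kind of group on that aromatic carbon, such as an amine or a methoxy group, would move the number beyond the scatter on either core. They also leave open whether a carboxylic acid in place of the methyl ester would do so.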